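From phenyl to 1-benzofuran-2-yl at the assay limit

The source may hold more compounds than are shown below. What is called first, only, known or untested is meant among the compounds shown, and "the series" means these compounds.

Of the compounds shown here, three sharing one core have been tested in a functional assay on HeLa S3 cells (Homo sapiens) for antiproliferative activity, read by XTT assay, with a stated time of 72 h; on this read-out higher numbers stand for weaker inhibition and lower numbers for stronger inhibition. Compound 1 (`Nc1nc2c(c(-c3ccco3)cn2[C@@H]2O[C@H](CO)[C@@H](O)[C@H]2O)c(=O)[nH]1`), with a furan-2-yl group, gives only a limit, > 20000 nM. Compound 2 (`Nc1nc2c(c(-c3cccs3)cn2[C@@H]2O[C@H](CO)[C@@H](O)[C@H]2O)c(=O)[nH]1`), with a thiophen-2-yl group, also gives only a limit, > 20000 nM. Compound 3 (`Nc1nc2c(c(-c3ccccc3)cn2[C@@H]2O[C@H](CO)[C@@H](O)[C@H]2O)c(=O)[nH]1`), with a phenyl group, likewise gives only a limit, > 20000 nM, so it has no numerical position in the series. The next structure, compound 4 (`Nc1nc2c(c(-c3cc4ccccc4o3)cn2[C@@H]2O[C@H](CO)[C@@H](O)[C@H]2O)c(=O)[nH]1`), has 1-benzofuran-2-yl in place of phenyl on an aromatic carbon.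

The measured exchanges of this group offer little guidance: a step that the two limits leave unreadable from compound 1 to compound 2, a step that the two limits leave unreadable from compound 1 to compound 3 and a step that the two limits leave unreadable from compound 2 to compound 3. None of them has a readable size, and the only common finding is the limit of > 20000 nM in this assay, at which 3 of the 3 values shown sit. Compound 4 is therefore expected to stay near this limit in this assay, most likely reported as a limit again, and no direction can be predicted. The expected step is a number no higher from compound 3 to compound 4 (the limit leaves the size open). For compound 4 the estimated value is 20000 nM, with an expected range from 8000 nM to 40000 nM.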

Compound 4, half-maximal inhibitory concentration: > 20000 nM
Compound 4: no number, only a limit (the forecaster's own chance of this, stated with the estimate: 80%); the middle value sits exactly at the limit.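

In this assay, among these compounds, compound 4 gives > 20000 nM, a limit and not a number, so no step to compound 4 from compound 1, compound 2 or compound 3 can be read. The compounds shown leave open whether furan-2-yl, thiophen-2-yl, phenyl and 1-benzofuran-2-yl differ at all: the limit of > 20000 nM in this assay, at which 4 of the 4 values shown sit.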